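Chloro in place of methoxy on compound 2

The compounds below may be only part of what the source reports. "The series", "measured", "known", "first", "only" and "open" are said of these compounds alone.

Measured so far in a functional assay on HeLa cells (Homo sapiens) for cytotoxicity, read by MTT assay, with a stated time of 48 h; a lower number here means a stronger inhibitor, a higher number a weaker inhibitor

Compound 1 `COc1ccc(/C=C/c2cc(OC)c(OC)c(OC)c2-c2ccc(OC)c(OC)c2)cc1` gives 45000 nM
Compound 2 `C=C(c1ccc(OC)cc1)c1cc(OC)c(OC)c(OC)c1-c1ccc(OC)cc1` gives 72000 nM

Compound 2, at 72000 nM, sits within the usual scatter of repeated measurements from compound 1 at 45000 nM, so these two numbers cannot be told apart. Both are large numbers on a scale where lower means stronger.

Compound 3 `C=C(c1ccc(OC)cc1)c1cc(OC)c(OC)c(OC)c1-c1ccc(Cl)cc1` keeps the core of compound 2 but has chloro in place of methoxy on an aromatic carbon, para to a large group (chloro in place of methoxy on an aromatic carbon). This turns a 4-methoxyphenyl into a 4-chlorophenyl.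

Among the compounds with values here, no measured pair here shows what such a swap does, so the best guide is compound 2 at 72000 nM, and no change beyond the scatter is expected in this assay. The expected step is small, a 1.4-fold lower number from compound 2 to compound 3 (0.16 log units; within the scatter). For compound 3 the estimated value is 50000 nM, with an expected range from 18000 nM to 120000 nM.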

Compound 3, half-maximal inhibitory concentration: 30000 nM
Compound 3: the middle estimate sits 1.7-fold (0.22 log units) above what was measured; the range from low to high includes it.
By their numbers in this assay, from the lowest: compounds 3, 1 and 2 (each within the scatter of the next, the first and the last beyond it).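

In this assay, chloro in place of methoxy on an aromatic carbon, para to a large group, brings a 2.4-fold lower number from compound 2 to compound 3 (0.38 log units; beyond the scatter). Within the data shown here, this is the first change that can be read as a single step, and it shows that the methoxy at this position can be given up without losing activity, although compound 3, at 30000 nM, still gives a large number on a scale where lower means stronger. Nothing available explains why the number moves with this swap.

Going by these compounds, it remains open whether chloro itself matters here or whether other groups at this position would do as well, such as fluoro, methyl, an amine or a carboxylic acid. On these data alone, it is also open whether the same swap would give a similar step on the core of compound 1.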